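Swapping the Outer Ring of a Biaryl Amide

The source may hold more compounds than are shown below. What is called first, only, known or untested is meant among the compounds shown, and "the series" means these compounds.

Compound 1, `CCOC(=O)CCCCCOc1cccc(CN(C(=O)c2ccc(-c3cccc(NC(C)=O)c3)cc2)C(C)C)c1`, gives in an ADME assay on BJ cells (Homo sapiens) for cytotoxicity, read by CellTiter-Glo and resazurin assay, with a stated time of 72 h (a lower number here means that less compound is needed, a higher number that more compound is needed for the effect), a value of > 26000 nM, which is a limit of the assay.
Compound 2, `CCOC(=O)CCCCCOc1cccc(CN(C(=O)c2ccc(-c3ccc4ccccc4c3)cc2)C(C)C)c1`, gives in this assay > 26000 nM, again a limit.
Compound 3, `CCOC(=O)CCCCCOc1cccc(CN(C(=O)c2ccc(-c3ccncc3)cc2)C(C)C)c1`, gives in this assay > 26000 nM, also a limit.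

Compound 3 therefore stands on a limit rather than a number, and the two other measured compounds sit on the same limit (the limit of > 26000 nM in this assay, at which 3 of the 3 values shown sit). The unmeasured compound 4, `CCOC(=O)CCCCCOc1cccc(CN(C(=O)c2ccc(-c3cccc(C(C)=O)c3)cc2)C(C)C)c1`, differs from compound 3 in one place: 3-acetylphenyl in place of pyridin-4-yl on an aromatic carbon.

Among the measured compounds shown here, two measured steps touch the pyridin-4-yl group that leaves: from compound 2 to compound 3 the step is a step that the two limits leave unreadable from compound 2 to compound 3, and from compound 1 to compound 3 it is a step that the two limits leave unreadable from compound 1 to compound 3. Neither has a readable size, since all values are limits. No direction can be read from them, so compound 4 is expected to stay on the same limit, with no step beyond the scatter.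

Compound 4 is expected at 30000 nM, with a range from 15000 nM to 60000 nM. The step this estimate means is a step that the limit leaves unreadable from compound 3 to compound 4, expected to lie within the scatter.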

Compound 4, half-maximal effective concentration: > 26000 nM
Compound 4 ended at the assay's limit; the forecaster's own chance of this, stated with the estimate: 85%; the middle value lies beyond the limit too.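

Among the compounds shown here, no step from compound 1, compound 2 or compound 3 to compound 4 can be read, because all four values are limits: the limit of > 26000 nM in this assay, at which 4 of the 4 values shown sit. The compounds shown leave open how these four truly compare in this assay, and whether any outer ring gives a readable value.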